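A few compounds are considered here, and "the series" means these few. Any claim that something is new, unique, unknown or untested is made for them only; others in the source may bear on it.

Measured compounds:
- compound 1, `CC(=O)n1cc(/C=C(/C(=O)O)c2ccc(Cl)cc2)c2cc(OCc3ccccc3)ccc21`: > 100000 nM
- compound 2, `COc1ccc(/C(=C\c2cn(C(C)=O)c3ccc(OCc4ccccc4)cc23)C(=O)O)cc1OC`: 96700 nM
- compound 3, `COc1ccc(/C(=C\c2c[nH]c3ccc(OCc4ccccc4)cc23)C(=O)O)cc1`: 38500 nM

The three compounds were tested in a functional assay on KB cells (Homo sapiens) for cytotoxicity, read by MTT assay, with a stated time of 72 h; a lower number here means a stronger inhibitor, a higher number a weaker inhibitor. Compound 1 returns only a limit of the assay, > 100000 nM, and no number. Compound 2 gives 96700 nM in this assay, and compound 3 gives 38500 nM. Where compound 1 stands can therefore only be bounded: its value is a limit, as noted in the limit of > 100000 nM in this assay, at which 1 of the 3 values shown sits, and it is not separated from compound 2 by anything beyond the scatter.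

Compound 4, `COc1cccc(/C(=C\c2cn(C(C)=O)c3ccc(OCc4ccccc4)cc23)C(=O)O)c1`, has not yet been measured in this assay. It differs from compound 1 in one place: 3-methoxyphenyl in place of 4-chlorophenyl on a double-bonded chain carbon bound to a carbonyl carbon and a double-bonded chain carbon. Among the measured compounds shown here, the one measured step that bears on this change is an at least 1.0-fold lower number from compound 1 to compound 2 (0.01 log units; that floor lies within the scatter), in which the 4-chlorophenyl group was likewise replaced by a methoxy-bearing phenyl ring at the same place; that step was at its floor and within the scatter. The shift from a chloro to a methoxy substituent on that ring therefore gave no movement that could be resolved, and a single 3-methoxyphenyl is expected to behave in the same way.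

Compound 4 is thus expected to be a weak inhibitor, with an expected step that the limit leaves unreadable from compound 1 to compound 4, and an estimated value of 110000 nM, ranging from 40000 nM to 300000 nM.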

Compound 4, half-maximal inhibitory concentration: > 100000 nM
Compound 4: no number, only a limit; the forecaster's own chance of this, stated with the estimate: 50%; the middle value does not contradict the limit.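

In this assay compound 4 gives > 100000 nM, which is a limit of the assay and not a number, so the 3-methoxyphenyl group at this place yields no readable value, just as the 4-chlorophenyl group did. With hydrogen in place of methoxy on an aromatic carbon, the change has an at least 1.0-fold higher number from compound 2 to compound 4 (0.01 log units; that floor lies within the scatter), so this second methoxy-related change at the ring, like the earlier step from 4-chlorophenyl, can only be bounded and shows no movement that can be resolved. The step between the two compounds held at the limit cannot be read, and this limit now recurs across the set: the limit of > 100000 nM in this assay, at which 2 of the 4 values shown sit.

The compounds shown leave open how far the true values of compound 1 and compound 4 lie beyond the limit, and so whether the two differ at all. They also leave open whether another group on this phenyl ring, such as an amine, a hydroxyl or a nitrile, would give a value clearly separated from the limit on the core of compound 4.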